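The source may hold more compounds than are shown below. What is called first, only, known or untested is meant among the compounds shown, and "the series" means these compounds.

Measured compounds:
compound 1 `C=C1C=CCO[C@@H]1n1ccc(NC(=O)c2ccccc2)nc1=O` — 296000 nM
compound 2 `C=C1[C@H](O)[C@H](O)CO[C@@H]1n1ccc(O)nc1=O` — >= 800000 nM
compound 3 `O=C1C=CCO[C@@H]1n1ccc(O)nc1=O` — 42000 nM

In a functional assay on HeLa cells (Homo sapiens), with a stated time of 3 days (on this read-out lower numbers stand for stronger inhibition and higher numbers for weaker inhibition), compound 1 gives 296000 nM. Compound 3 gives 42000 nM in this assay. For compound 2 this assay reports only a limit, >= 800000 nM, and no number. That limit is the limit of >= 800000 nM in this assay, at which 1 of the 3 values shown sits, and compound 2 is the single one of the three that sits on it; the other two compounds carry numbers. On the numbers shown, compound 2 therefore stands at the weak end of the series, without a value that could be placed against the others.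

Compound 4 `C=C1[C@H](O)[C@H](O)CO[C@@H]1n1cc(C)c(O)nc1=O` differs from compound 2 by methyl in place of hydrogen on an aromatic carbon. Going by the values given here, no step between two measured compounds is available for this change, so its size cannot be read from the series. A single methyl entering for a hydrogen is a small change, and with compound 2 already at the limit, no step beyond the scatter is expected in this assay: the expected step is a number no higher from compound 2 to compound 4 (the limit leaves the size open). Compound 4 is accordingly estimated at 800000 nM, with a range from 300000 nM to 2000000 nM, and most likely this assay will again return only a limit for compound 4.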

Compound 4, half-maximal inhibitory concentration: >= 800000 nM
Compound 4 ended at the assay's limit; the forecaster's own chance of this, stated with the estimate: 80%; the middle value lies on the limit itself.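

Compound 2 and compound 4 both return only a limit in this assay, so no step can be read between them: the limit of >= 800000 nM in this assay, at which 2 of the 4 values shown sit.

Still open, going by these compounds, is whether methyl in place of hydrogen on an aromatic carbon changes the read-out in this assay at all; neither compound 2 nor compound 4 carries a number there.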